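The compounds below may be only part of what the source reports. "The series", "measured", "known", "first", "only" and "open" are said of these compounds alone.

Compound 1 `O=C1/C(=C/c2ccncc2)CN(S(=O)(=O)c2ccc(F)cc2)C/C1=C\c1ccccc1F` gives 9100 nM in a functional assay on QGY-7703 cells (Homo sapiens) for cytotoxicity, read by MTT assay, with a stated time of 24 h; a lower number here means a stronger inhibitor, a higher number a weaker inhibitor. Compound 2 `O=C1/C(=C/c2ccncc2)CN(S(=O)(=O)c2ccc(Cl)cc2)C/C1=C\c1ccccc1F` gives 12500 nM. Compound 3 `O=C1/C(=C/c2cccnc2)CN(S(=O)(=O)c2ccc(F)cc2)C/C1=C\c1ccccc1C(F)(F)F` gives 6030 nM, and compound 4 `O=C1/C(=C/c2cccnc2)CN(S(=O)(=O)c2ccc(Cl)cc2)C/C1=C\c1ccccc1C(F)(F)F` has not yet been measured.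

Compound 2 differs from compound 1 by chloro in place of fluoro on an aromatic carbon, and this change made a step of a 1.4-fold higher number from compound 1 to compound 2 (0.14 log units; within the scatter). Compound 3 and compound 1 have different cores; the difference between the two cores is not broken down here. Compound 4 differs from compound 3 by chloro in place of fluoro on an aromatic carbon, the same change as that from compound 1 to compound 2. Because the earlier step was a 1.4-fold higher number from compound 1 to compound 2 (0.14 log units; within the scatter), compound 4 is expected to sit close to compound 3, with an estimated step of a 1.4-fold higher number from compound 3 to compound 4 (0.14 log units; within the scatter). On that basis compound 4 is estimated at 8400 nM in this assay, with a range from 4000 nM to 17000 nM.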

Compound 4, half-maximal inhibitory concentration: 3440 nM
Estimate against measurement, compound 4: 2.4-fold (0.39 log units) above, outside the stated range (below it).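

In this assay, replacing (4-fluorophenyl)sulfonyl with (4-chlorophenyl)sulfonyl gave a 1.8-fold lower number from compound 3 to compound 4 (0.24 log units; within the scatter). Set beside the same change on the other core, this gives no sign that the change behaves differently on the two cores: the same change on two cores in this assay, a 1.4-fold higher number (0.14 log units; within the scatter) from compound 1 to compound 2 and a 1.8-fold lower number (0.24 log units; within the scatter) from compound 3 to compound 4, 2.4-fold (0.38 log units) apart, within the scatter of two such steps This shows only that, on these two cores, the change produced no step beyond the scatter; it does not show that the change has a real effect of its own, or that the same would hold on any further core.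

The compounds shown leave open what a methoxy group, a nitrile or an amine would give in place of the fluoro or chloro. They also leave open which of the several differences between the two cores matter, since no single one is isolated here.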